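Swapping One Aryl Group on a Shared Core

The compounds below may be only part of what the source reports. "The series", "measured", "known", "first", "only" and "open" are said of these compounds alone.

Measured compounds:
compound 1 `Cc1oc(=O)n(C(=O)NCCCCc2ccccc2)c1-c1ccccc1` — 42 nM
compound 2 `O=C(NCCCCc1ccccc1)n1cc(-c2ccc(Cl)cc2)oc1=O` — 83 nM

In an assay on isolated protein for inhibition of acid ceramidase (Homo sapiens), read by LC-MS, with a stated time of 1 h (on this read-out lower numbers stand for stronger inhibition and higher numbers for weaker inhibition), compound 1 gives 42 nM and compound 2 gives 83 nM. Compound 2 holds the higher of the two numbers, but its gap to compound 1 lies within the scatter, so neither compound can be called the stronger inhibitor on this evidence.

Compound 3 `COc1ccccc1-c1cn(C(=O)NCCCCc2ccccc2)c(=O)o1` is not yet measured. It differs from compound 2 in a single place: 2-methoxyphenyl in place of 4-chlorophenyl on an aromatic carbon. Among the measured compounds shown here, no pair of measured compounds isolates this change, so there is no precedent for its size or direction. For the measured compounds named here, with only two measured compounds, both within scatter of each other, the step of a 1.4-fold higher number from compound 2 to compound 3 (0.16 log units; within the scatter) is expected to be modest and may well fall inside the scatter. Compound 3 is therefore expected to give about 120 nM in this assay, within a range from 40 nM to 400 nM.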

Compound 3, half-maximal inhibitory concentration: 177 nM
Beside the measured number, compound 3's estimate is 1.5-fold (0.17 log units) below it; measured number inside the range.
By their numbers in this assay, from the lowest: compounds 1 and 2 (each within the scatter of the next); then compound 3.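

Replacing 4-chlorophenyl with 2-methoxyphenyl on the aromatic carbon next to the ring oxygen gives a 2.1-fold higher number from compound 2 to compound 3 (0.33 log units; beyond the scatter) in this assay and is the only step shown that is measured beyond the scatter. This position therefore responds to a change of its aryl group, though only modestly, and the step is a single swap that alters both the substituent on the phenyl ring and where that substituent sits, so the two cannot be separated here. The data offer no measurement that explains the step.

As far as these compounds go, whether the substituent itself or its place on the phenyl ring matters more remains open, and 4-methoxyphenyl or 2-chlorophenyl at this position would separate the two. From the compounds shown here alone, how a pyridine ring or a carboxylic acid on the phenyl ring would fare at this carbon also remains open.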